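This account rests on a few compounds, and the source may have more. Where it says the series, first, only, none or still open, it means among the compounds named here.

Working notes on the series. For the measured compounds named here, in a functional assay on K562 cells (Homo sapiens) for antiproliferative activity, read by CCK-8 assay, with a stated time of 72 h (on this read-out lower numbers stand for stronger inhibition of growth and higher numbers for weaker inhibition of growth), compound 1 (`CCC1C(=O)N(C)c2cnc(Nc3ccc(S(=O)(=O)NC)cc3)nc2N1c1ccn(C)n1`) gives 2890 nM, the second highest of the three numbers measured so far. Compound 2 (`CC[C@@H]1C(=O)N(C)c2cnc(-n3ccc4cc(C(N)=O)ccc43)nc2N1C1CCCC1`), at 1850 nM, lies within the scatter of that value. Compound 3 (`CCC1C(=O)N(C)c2cnc(-n3ccc4cc(C(=O)NC)ccc43)nc2N1c1ccn(C)n1`), at 13300 nM, has a higher number than compound 1, and that gap is beyond the scatter.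

Compound 4 (`CCCNS(=O)(=O)c1ccc(Nc2ncc3c(n2)N(c2ccn(C)n2)C(CC)C(=O)N3C)cc1`) keeps the core of compound 1 and alters only the sulfonamide side chain: ethyl in place of hydrogen on a saturated chain carbon bound to a sulfonamide nitrogen. This places ethyl in place of hydrogen on a saturated chain carbon bound to a sulfonamide nitrogen, so methylsulfamoyl becomes propylsulfamoyl.

Going by the values given here, no two measured compounds differ in one place, so the size of this change has not been measured directly. The expectation therefore rests on compound 1 at 2890 nM, and no step beyond the scatter is expected in this assay, with no firm direction. The range is kept wide to reflect how little the three measured values can show about this change.

The expected result is a 1.0-fold higher number from compound 1 to compound 4 (0.02 log units; within the scatter). For compound 4 the estimated value is 3000 nM, with an expected range of 1100 nM to 8000 nM.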

Compound 4, concentration for 50% growth inhibition: 2260 nM
For compound 4 the middle estimate is 1.3-fold (0.12 log units) above the measured one; measured number inside the range.
By their numbers in this assay, from the lowest: compounds 2, 4 and 1 (each within the scatter of the next); then compound 3.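

The pair gives the series its first direct reading at this place. In this assay, ethyl in place of hydrogen on a saturated chain carbon bound to a sulfonamide nitrogen, which turns methylsulfamoyl into propylsulfamoyl, gives a 1.3-fold lower number from compound 1 to compound 4 (0.11 log units; within the scatter), so the two numbers cannot be told apart and, on this one pair, the longer chain is accommodated in this assay without a step beyond the scatter. No measurement at hand bears on why the two numbers stand so close.

Still open, as far as these compounds go, is how far this tolerance reaches along the side chain: a longer chain such as butyl, a branched chain such as isopropyl, a ring such as cyclopropyl, or a chain ending in an amine or a carboxylic acid could each read differently, and a single pair says nothing about them. Also open, from the compounds shown here alone, is whether the same change from methylsulfamoyl to propylsulfamoyl would read alike if the rest of compound 1 carried other groups.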